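A Methyl on the Imidazole Ring, Applied Twice

The source may hold more compounds than are shown below. What is called first, only, known or untested is meant among the compounds shown, and "the series" means these compounds.

Three compounds were tested in a functional assay on the whole organism for antagonist activity, with Mus musculus as the target; a higher number here means that more compound is needed for the effect, a lower number that less compound is needed. Compound 1 `CC(C#CCn1ccnc1)N1CCCC1=O` gives 2 mg/kg in this assay. Compound 2 `Cc1cncn1CC#CC(C)N1CCCC1=O` carries the change methyl in place of hydrogen on an aromatic carbon and gives 0.45 mg/kg in this assay, a step described as a 4.4-fold lower number from compound 1 to compound 2 (0.65 log units; beyond the scatter). Compound 3 `CC(=O)N(C)CC#CCn1ccnc1` has a different core, and the difference between the two cores is not broken down here. In this assay compound 3 reaches only the limit of the assay, > 100 mg/kg, which is not a number. This is the limit described as the limit of > 100 mg/kg in this assay, at which 1 of the 3 values shown sits.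

Compound 4 `CC(=O)N(C)CC#CCn1cncc1C` has not yet been measured. It differs from compound 3 by methyl in place of hydrogen on an aromatic carbon. This is the same kind of change as that from compound 1 to compound 2, though the surroundings are described a little differently: in the earlier pair the methyl enters next to the ring atom that bears a large group, while in the new pair it enters next to the ring atom that bears a group of 9 heavy atoms.

For compound 4 in this assay the expected step is a number no higher from compound 3 to compound 4 (the limit leaves the size open), resting on the step of a 4.4-fold lower number from compound 1 to compound 2 (0.65 log units; beyond the scatter) in the earlier pair and on the fact that compound 3 gives only the limit > 100 mg/kg. Because compound 3 sits at the limit of > 100 mg/kg in this assay, at which 1 of the 3 values shown sits, the estimate for compound 4 is most likely to be reported again as a limit rather than a number. The estimated value for compound 4 in this assay is 100 mg/kg, with a range from 20 mg/kg to 400 mg/kg.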

Compound 4, dose for half-maximal effect: 6.6 mg/kg
The estimate for compound 4 lay 15-fold (1.18 log units) above the measured number; measured number outside the range, below it.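

In this assay, methyl in place of hydrogen on an aromatic carbon gives an at least 15-fold lower number from compound 3 to compound 4 (1.18 log units; beyond the scatter), which goes the same way as a 4.4-fold lower number from compound 1 to compound 2 (0.65 log units; beyond the scatter), but the two steps do not match in size: the same change on two cores in this assay, a 4.4-fold lower number (0.65 log units; beyond the scatter) from compound 1 to compound 2 and an at least 15-fold lower number (1.18 log units; beyond the scatter) from compound 3 to compound 4, at least 3.4-fold (0.53 log units) apart, beyond the scatter of two such steps

Compound 3 gives > 100 mg/kg, which is a limit of the assay and not a number, so the step on its core has only a lower bound and no exact size: the limit of > 100 mg/kg in this assay, at which 1 of the 4 values shown sits.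

The change therefore lowered the number on both cores shown, but its size on the core of compound 1 did not carry over to the core of compound 3, and two pairs set no rule for other cores in this series.

The compounds shown leave open whether an ethyl group or a chlorine atom on that same aromatic carbon would lower the number as the methyl does. They also leave open whether the methyl would have a similar effect on a core that carries an amine or a carboxylic acid on its chain.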